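Two-carbon linker variants on a shared naphthyl-pyridine core

The compounds below may be only part of what the source reports. "The series", "measured", "known", "first", "only" and "open" are said of these compounds alone.

Measured so far:
Compound 1 `CNC(=O)/C=C/c1ccncc1-c1ccc2ccccc2c1` — 6550 nM
Compound 2 `COC(=O)COc1ccncc1-c1ccc2ccccc2c1` — "not determined" (no result reported)
Compound 3 `COC(=O)CCc1ccncc1-c1ccc2ccccc2c1` — "not determined" (no result reported)

Only compound 1 has been read in a functional assay on HCT-116 cells (Homo sapiens) for inhibition, read by MTT assay, with a stated time of 72 h (on this read-out lower numbers stand for stronger inhibition of growth and higher numbers for weaker inhibition of growth), where compound 1 gives 6550 nM. Compound 2 and compound 3 share the same core but carry no result in this assay: compound 2 gives "not determined" (no result reported) and compound 3 gives "not determined" (no result reported), so compound 3 stands without any number of its own, and the other compound without a number gives no help either.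

Compound 4 `CCOC(=O)/C=C/c1ccncc1-c1ccc2ccccc2c1` differs from compound 3 in a single place: 2-(ethoxycarbonyl)ethenyl in place of 2-(methoxycarbonyl)ethyl on an aromatic carbon. Among the compounds with values here, no measured pair in this set maps such a change, so the size and direction of the step from compound 3 to compound 4 in this assay cannot be read from the data; the only anchor is the value of compound 1, which also carries two double bonds outside aromatic rings in the same place.

Taking compound 1 as the nearest measured neighbour, compound 4 is expected to give about 9000 nM in this assay, with a plausible range from 2000 nM to 40000 nM; a limit rather than a number is also possible.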

Compound 4, concentration for 50% growth inhibition: 910 nM
Beside the measured number, compound 4's estimate is 9.9-fold (1.00 log units) above it; measured number outside the range, below it.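

In this assay, the chain on the aromatic carbon opposite the ring nitrogen now has a second reading, and the change at its carbonyl carbon, ethoxy in place of methylamino, gives a 7.2-fold lower number from compound 1 to compound 4 (0.86 log units; beyond the scatter). Within the data shown here, this is the first sign that the group on this carbonyl carbon matters for growth inhibition in these cells, with the ester of compound 4 giving the lower number of the two. Nothing measured here gives a reason for this step.

Steps involving compound 2 or compound 3 cannot be read, so the effect of the saturated 2-(methoxycarbonyl)ethyl chain against the ethenyl chain remains open. Also open, as far as these compounds go, is how a carboxylic acid, a tertiary amide or a longer ester chain at this carbonyl would read.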